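Ethoxy in place of fluoro on compound 1

The source may report more compounds than this note shows. Statements on the series, on what has been measured and on what is new or still open speak of the compounds shown alone.

Compound 1 (`C=C(Br)C(=O)Nc1cccc(/C=C/C(=O)Nc2ccc(F)cc2)c1`) gives 16600 nM in a functional assay on CCRF-CEM cells (Homo sapiens) for inhibition, read by MTT assay, with a stated time of 72 h (a higher number here means a weaker inhibitor, a lower number a stronger inhibitor), and compound 2 (`C=C(Br)C(=O)Nc1cccc(/C=C/C(=O)Nc2cccc(F)c2)c1`) gives 26000 nM there, two values within the scatter of each other. Compound 3 (`C=C(Br)C(=O)Nc1cccc(/C=C/C(=O)Nc2ccc(OCC)cc2)c1`) has ethoxy in place of fluoro on an aromatic carbon, para to a large group (ethoxy in place of fluoro on an aromatic carbon). Going by the values given here, the one measured step (a 1.6-fold higher number from compound 1 to compound 2 (0.19 log units; within the scatter)) lies within the scatter and keeps fluoro, so it bears only weakly on ethoxy. No step beyond the scatter is therefore expected in this assay in either direction, and the estimated step is small (a 1.1-fold higher number from compound 1 to compound 3 (0.04 log units; within the scatter)). For compound 3 the estimated value is 18000 nM (range 7000 nM to 45000 nM).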

Compound 3, half-maximal inhibitory concentration: 98 nM
Compound 3: the middle estimate sits 180-fold (2.26 log units) above what was measured, and the stated range ends above it.
By their numbers in this assay, from the lowest: compound 3; then compounds 1 and 2 (each within the scatter of the next).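

At this aromatic carbon, para to a large group, the choice of group can matter far more than compounds 1 and 2 indicated: in this assay, ethoxy in place of fluoro gives a 170-fold lower number from compound 1 to compound 3 (2.23 log units; beyond the scatter), whereas the two fluoro compounds stand within the scatter of each other. The position is therefore not insensitive to change. No measurement shown gives a reason for this gain.

The compounds leave open whether methoxy, a longer chain such as butoxy, or an amine at this position would give a similarly low number. They also leave open whether the oxygen or the two carbons of ethoxy matter more.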